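Removing a nitro from the core of compound 2

The source may hold more compounds than are shown below. What is called first, only, known or untested is meant among the compounds shown, and "the series" means these compounds.

Measured so far in a functional assay on HCT-116 cells (Homo sapiens) for cytotoxicity, read by MTT assay; a lower number here means a stronger inhibitor, a higher number a weaker inhibitor:
- Compound 1 `NS(=O)(=O)c1nnc(NCc2nc3cc([N+](=O)[O-])ccc3[nH]2)s1` gives 176000 nM
- Compound 2 `O=[N+]([O-])c1ccc2[nH]c(CNc3c([N+](=O)[O-])ccc4ncccc34)nc2c1` gives 256000 nM
- Compound 3 `COc1ccc2c(c1)CCC/C2=N\NCc1nc2ccccc2[nH]1` gives 41000 nM

Compound 2 carries the highest of the three numbers in this assay. Its nearest neighbour is compound 1, whose number is within the scatter of that of compound 2, so the two cannot be ordered against each other. Compound 3 stands furthest from it, with a number that is lower by a margin beyond the scatter. Compound 3 shares with compound 2 only the benzimidazole-methylamine part, attached to a different core, so no single change connects the two.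

Compound 4 `O=[N+]([O-])c1ccc2ncccc2c1NCc1nc2ccccc2[nH]1` differs from compound 2 in one place: hydrogen in place of nitro on an aromatic carbon. Within the data shown here, no pair of measured compounds separated by this kind of change is available, so the size of this step in this assay has to be guessed from the three numbers alone. He expects no step beyond the scatter, or at most a small one toward a lower number, since compound 1 with its nitro and compound 2 with two nitro groups sit within the scatter of each other. For compound 4 he therefore estimates 200000 nM, within a range of 60000 nM to 600000 nM, a step of a 1.3-fold lower number from compound 2 to compound 4 (0.11 log units; within the scatter).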

Compound 4, half-maximal inhibitory concentration: 204000 nM
Compound 4: the middle estimate sits 1.0-fold (0.01 log units) below what was measured; measured number inside the range.
By their numbers in this assay, from the lowest: compound 3; then compounds 1, 4 and 2 (each within the scatter of the next).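

In this assay, among these compounds, the exchange of nitro for hydrogen on this aromatic carbon of the six-membered ring of carbon only gives a 1.3-fold lower number from compound 2 to compound 4 (0.10 log units; within the scatter) and so supplies the first measured step of this kind. Within this pair the nitro at this position can thus be lost with no change that this assay can distinguish from scatter, and compound 4, which keeps its other nitro, cannot be ordered against compound 2. Among the compounds shown here, this single pair shows only that the step is small here, and no measurement at hand bears on why that is so.

The compounds shown leave open whether another group on the same aromatic carbon, such as an amine, a methoxy group or a carboxylic acid, would move the number beyond the scatter. They also leave open whether hydrogen in place of the other nitro of compound 4 would be as small a step, or whether the same exchange would behave alike on another core.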